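The source may hold more compounds than are shown below. What is called first, only, known or untested is meant among the compounds shown, and "the series" means these compounds.

In an ADME assay on HUVEC cells (Homo sapiens) for antiproliferative activity, read by MTT assay, with a stated time of 48 h (a higher number here means a weaker inhibitor, a lower number a stronger inhibitor), compound 1 `Cc1cccc(-n2nncc2CN2C(=O)C3(C(C#N)=C(N)Oc4c(N)cc5nc6ccccc6nc5c43)c3ccccc32)c1` gives only a limit, > 50000 nM. Compound 2 `CCc1ccccc1-n1nncc1CN1C(=O)C2(C(C#N)=C(N)Oc3c(N)cc4nc5ccccc5nc4c32)c2ccccc21` likewise gives only a limit, > 50000 nM. Compound 3 `Cc1ccc(-n2nncc2CN2C(=O)C3(C(C#N)=C(N)Oc4c(N)cc5nc6ccccc6nc5c43)c3ccccc32)cc1C` also stops at a limit, > 50000 nM, which places it at the bound where every value shown so far sits (the limit of > 50000 nM in this assay, at which 3 of the 3 values shown sit). Compound 4 `Cc1ccc(C)c(-n2nncc2CN2C(=O)C3(C(C#N)=C(N)Oc4c(N)cc5nc6ccccc6nc5c43)c3ccccc32)c1` differs from compound 3 by 2,5-dimethylphenyl in place of 3,4-dimethylphenyl on an aromatic nitrogen. The steps that touch this part of the molecule, a step that the two limits leave unreadable from compound 1 to compound 2, a step that the two limits leave unreadable from compound 1 to compound 3 and a step that the two limits leave unreadable from compound 2 to compound 3, are all unreadable, with both of their ends resting at the limit. No step beyond the scatter is therefore expected in this assay from this change, and the read-out is expected to remain at the limit. Compound 4 is estimated at 60000 nM, between 20000 nM and 200000 nM, the expected step being a step that the limit leaves unreadable from compound 3 to compound 4.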

Compound 4, half-maximal inhibitory concentration: > 50000 nM
Compound 4: only a limit was reported; the forecaster's own chance of this, stated with the estimate: 85%; the middle value is on the limit's open side.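

In this assay compound 4 gives only a limit, > 50000 nM, so its steps from compound 1, compound 2 and compound 3 cannot be read. The compounds shown leave open whether any group on the aromatic nitrogen would give a value past the limit: the limit of > 50000 nM in this assay, at which 4 of the 4 values shown sit.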